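Side-chain variation and cytotoxicity: notes toward compound 3

This account rests on a few compounds, and the source may have more. Where it says the series, first, only, none or still open, it means among the compounds named here.

Within the data shown here, compound 2 `CC(C)=CC[C@@H](OC(=O)CCO)C1=CC(=O)c2c(O)ccc(O)c2C1=O` holds the highest of the two numbers so far in a functional assay on HeLa cells (Homo sapiens) for cytotoxicity, read by MTT assay (a higher number here means a weaker inhibitor, a lower number a stronger inhibitor), at 67600 nM; its only neighbour, compound 1 `CC(=O)OCCO[C@H](CC=C(C)C)C1=CC(=O)c2c(O)ccc(O)c2C1=O`, gives 41500 nM in this assay, and the step of a 1.6-fold higher number from compound 1 to compound 2 (0.21 log units; within the scatter) lies within the scatter, so the two values are not to be ordered. Compound 3 `CC(=O)OC(C)CO[C@H](CC=C(C)C)C1=CC(=O)c2c(O)ccc(O)c2C1=O` is not yet measured. The change is 2-acetoxypropyl in place of (2-hydroxyethyl)carbonyl on an oxygen on a saturated carbon. Among the measured compounds shown here, the one measured step that bears on it, a 1.6-fold higher number from compound 1 to compound 2 (0.21 log units; within the scatter), exchanged a 2-acetoxyethyl side chain for a (2-hydroxyethyl)carbonyl one on the same oxygen with no shift beyond the scatter; compound 3 carries 2-acetoxypropyl, the nearer relative of the side chain of compound 1. Nothing in the series shows movement in this assay for exchanges of this kind, so the expected step is none beyond the scatter, a 1.5-fold lower number from compound 2 to compound 3 (0.18 log units; within the scatter). Compound 3 is estimated at 45000 nM in this assay, with a range from 15000 nM to 140000 nM.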

Compound 3, half-maximal inhibitory concentration: 40100 nM
Beside the measured number, compound 3's estimate is 1.1-fold (0.05 log units) above it; low and high end bracket the measured number.
By their numbers in this assay, from the lowest: compounds 3, 1 and 2 (each within the scatter of the next).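

In this assay, 2-acetoxypropyl in place of (2-hydroxyethyl)carbonyl on the oxygen on a saturated carbon gives a 1.7-fold lower number from compound 2 to compound 3 (0.23 log units; within the scatter), so a third side chain at this position also stays within the scatter. Methyl in place of hydrogen on a saturated chain carbon bound to an oxygen next to a carbonyl group and a saturated chain carbon gives a 1.0-fold lower number from compound 1 to compound 3 (0.01 log units; within the scatter), the first reading of a change made within the side chain itself, and it too shows no shift beyond the scatter. No evidence on why these numbers stay so close is at hand.

Still open, as far as these compounds go, is whether an amine or a carboxylic acid in this side chain, or a longer chain on the same oxygen, would give a step beyond the scatter. Also open, from the compounds shown here alone, is how far the number depends on the shared core, which is the same in compound 1, compound 2 and compound 3.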